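Adding one methyl to the ethoxy group of compound 1

This account rests on a few compounds, and the source may have more. Where it says the series, first, only, none or still open, it means among the compounds named here.

Compound 1 `CCOc1ccc(NC(=O)C(=O)c2cn(C(C)C)c3ccccc23)cn1`: 175 nM
Compound 2 `CCn1cc(C(=O)C(=O)Nc2ccc(OC)nc2)c2ccccc21`: 219 nM

In a functional assay on FaDu cells (Homo sapiens) for cytotoxicity, read by MTT assay, with a stated time of 72 h (on this read-out lower numbers stand for higher toxicity in this test and higher numbers for lower toxicity in this test), compound 1 and compound 2 stand level: their two numbers lie within the usual scatter of repeated measurements, so neither can be ranked above the other. Compound 3 `CC(C)Oc1ccc(NC(=O)C(=O)c2cn(C(C)C)c3ccccc23)cn1` has not yet been measured. It keeps the core of compound 1 and alters only the ethoxy group, which becomes isopropoxy (methyl in place of hydrogen on a saturated chain carbon bound to an oxygen on an aromatic ring and a saturated chain carbon). In words, a methyl takes the place of a hydrogen on a saturated chain carbon bound to an oxygen on an aromatic ring and a saturated chain carbon. Among the compounds with values here, no measured pair isolates this change, so the only guide is compound 1 at 175 nM and no shift beyond the scatter is expected. The estimated change is a 1.1-fold higher number from compound 1 to compound 3 (0.04 log units; within the scatter) and that is a small one. For compound 3 the expected value is 190 nM within an estimated range from 85 nM to 420 nM in this test.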

Compound 3, concentration lethal to 50% of the cells: 408 nM
Estimate against measurement, compound 3: 2.1-fold (0.33 log units) below; the measured number falls inside the stated range.
By their numbers in this assay, from the lowest: compounds 1, 2 and 3 (each within the scatter of the next, the first and the last beyond it).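

Turning the ethoxy group into isopropoxy gives a 2.3-fold higher number from compound 1 to compound 3 (0.37 log units; beyond the scatter) in this assay. A single methyl on this saturated chain carbon is therefore enough to move the number beyond the usual scatter, towards lower toxicity in this test, which compound 1 and compound 2 could not show because they differ in more than one place. Nothing available explains why this methyl has that effect.

Still open, going by these compounds, is whether the number would keep rising with a bulkier tert-butoxy group or a longer propoxy chain, or would return towards that of compound 1 with an amine in place of the ethoxy group. A single step also cannot tell whether the same methyl would shift the number similarly on a different core.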